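A few compounds are considered here, and "the series" means these few. Any claim that something is new, unique, unknown or untested is made for them only; others in the source may bear on it.

Measured compounds and their numbers:

compound 1 `O=C1C(Nc2ccc(I)cc2)=CC(=O)c2ncncc21`: 0.04 ug/mL
compound 2 `O=C1C(Nc2ccc(Br)cc2)=CC(=O)c2ncncc21`: 0.02 ug/mL

Both numbers come from a functional assay on SK-OV-3 cells (Homo sapiens) for cytotoxicity, read by MTT assay, with a stated time of 72 h; a lower number here means a stronger inhibitor, a higher number a weaker inhibitor. Among the compounds with values here, compound 2 and compound 1 sit within the scatter of each other; the only measured step, a 2.0-fold lower number from compound 1 to compound 2 (0.30 log units; within the scatter), does not separate them, so compound 2 stands alongside compound 1 rather than apart from it.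

Compound 3 `O=C1C(Nc2ccc(Cl)cc2)=CC(=O)c2ncncc21` has not been measured. Its difference from compound 2 is chloro in place of bromo on an aromatic carbon, at the same place as the halogen exchange in the measured step.

Within the data shown here, the one step that bears on this change is the exchange from compound 1 to compound 2, a halogen for a halogen on the same aromatic carbon, which gave a 2.0-fold lower number from compound 1 to compound 2 (0.30 log units; within the scatter). That step stayed within the scatter, and nothing in the two numbers at hand suggests a second halogen exchange at the same carbon would behave differently. No step beyond the scatter is therefore expected in this assay, in either direction.

Compound 3 is estimated at 0.03 ug/mL, with a range from 0.01 ug/mL to 0.1 ug/mL. The estimated step is a 1.5-fold higher number from compound 2 to compound 3 (0.18 log units; within the scatter), inside the scatter.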

Compound 3, half-maximal inhibitory concentration: 0.01 ug/mL
For compound 3 the middle estimate is 3.0-fold (0.48 log units) above the measured one; the measured number falls inside the stated range.
By their numbers in this assay, from the lowest: compounds 3, 2 and 1 (each within the scatter of the next, the first and the last beyond it).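

In this assay the halogen on this aromatic carbon now spans chloro, bromo and iodo, and the newest exchange, a 2.0-fold lower number from compound 2 to compound 3 (0.30 log units; within the scatter), leaves chloro and bromo as unseparated as the earlier exchange left bromo and iodo. Within the data shown here, what the earlier compounds could not show appears only across the whole set: a 4.0-fold lower number from compound 1 to compound 3 (0.60 log units; beyond the scatter), is the first step at this position to clear the scatter, and it is modest, with compound 2 not separated from either of the other two. Nothing at hand accounts for the separation between the chloro and iodo compounds.

On these data alone, all three compounds carry a halogen on the same carbon, so it remains open how fluoro, or a group other than a halogen, such as methoxy, an amine or a carboxylic acid, would read at this place on the otherwise unchanged core. Also open is whether the modest separation of chloro from iodo would hold in other cell lines or on repeated measurement, as every number shown comes from one cytotoxicity read-out.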